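The compounds below may be only part of what the source reports. "The series", "measured", "known", "first", "only" and "open" are said of these compounds alone.

In a functional assay (trachea) with Cavia porcellus as the target (on this read-out lower numbers stand for an effect already at smaller amounts and higher numbers for an effect only at larger amounts of compound), compound 1 `C=CCCn1c(=O)c2[nH]cnc2n(CCC)c1=O` gives 200 nM, compound 2 `CCCn1c(=O)n(CCOCC)c(=O)c2[nH]cnc21` gives 70 nM, and compound 3 `C=CCCn1cnc2c1c(=O)n(C)c(=O)n2CCC` gives 16800 nM. Compound 3 thus holds the highest of the three numbers, beyond the scatter from both others, lying nearest to compound 1 and furthest from compound 2.

Compound 4 `CCCn1c(=O)n(C)c(=O)c2c1ncn2CCCN(C)C` has no value yet in this assay. Its difference from compound 3 is (dimethylamino)methyl in place of vinyl on a saturated chain carbon, two bonds along the chain from an aromatic nitrogen. Cut one bond further out, this reads but-3-en-1-yl to 3-(dimethylamino)propyl.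

Among the measured compounds shown here, only one measured step bears on this change: a 2.9-fold lower number from compound 1 to compound 2 (0.46 log units; beyond the scatter), with ethoxy in place of vinyl on the same kind of chain carbon. That step is modest, but it involves a different entering group and another aromatic nitrogen of the shared core, so it is a weak guide. For the measured compounds named here, no measured pair tests an amine-bearing chain.

A modest move towards a lower number in this assay is therefore expected, though a result within the scatter would not be surprising. The expected size is a 1.9-fold lower number from compound 3 to compound 4 (0.27 log units; within the scatter). For compound 4 the estimated value is 9000 nM, with an expected range of 2500 nM to 35000 nM.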

Compound 4, half-maximal effective concentration: > 100000 nM
Compound 4: only a limit was reported; the forecaster's own chance of this, stated with the estimate: 15%; middle value at least 11-fold (1.04 log units) from the limit.
By their numbers in this assay, from the lowest: compound 2; then compound 1; then compound 3. At a limit, above all of these: compound 4.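

In this assay, among the compounds shown here, the change from but-3-en-1-yl to 3-(dimethylamino)propyl gives an at least 5.9-fold higher number from compound 3 to compound 4 (0.77 log units; beyond the scatter), so a chain ending in a dimethylamino group is the first substitution here to move the number upwards. The direction is opposite to a 2.9-fold lower number from compound 1 to compound 2 (0.46 log units; beyond the scatter), where ethoxy replaces vinyl on the same kind of chain carbon, so on this kind of carbon the entering group can decide the direction of the step, although the two steps sit on different aromatic nitrogens of the shared core and cannot be equated. Compound 4 gives > 100000 nM, which is a limit and not a number, so the step marks only a minimum size and the compound cannot be placed exactly: the limit of > 100000 nM in this assay, at which 1 of the 4 values shown sits.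

Going by these compounds, it remains open whether a 2-ethoxyethyl chain on the aromatic nitrogen carrying the chain in compound 3 would lower the number as ethoxy does in compound 2, which would show whether the position or the entering group governs the direction. Also open, on these data alone, is whether the rise follows the amine itself, which a primary amine, a morpholine or a shorter 2-(dimethylamino)ethyl chain could test.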